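The compounds below may be only part of what the source reports. "The series", "measured", "known", "first", "only" and "open" are said of these compounds alone.

Compound 1, `O=C(CCc1ccc(C(F)(F)F)cc1)Nc1ccc2nc(N3CCC3)ccc2c1`, gives 4 nM in an assay on isolated protein for displacement of a labelled ligand from melanin-concentrating hormone receptor 1 (Homo sapiens); on this read-out lower numbers stand for stronger inhibition and higher numbers for weaker inhibition.
Compound 2, `CC(C)N(C)c1ccc2cc(NC(=O)CCc3ccc(C(F)(F)F)cc3)ccc2n1`, gives 2 nM in this assay.
Compound 3, `CN(c1ccc2cc(NC(=O)CCc3ccc(C(F)(F)F)cc3)ccc2n1)C1CCCCC1`, gives 18 nM in this assay.

Of these three numbers, compound 3 has the highest: the step of a 4.5-fold higher number from compound 1 to compound 3 (0.65 log units; beyond the scatter) and the step of a 9.0-fold higher number from compound 2 to compound 3 (0.95 log units; beyond the scatter) both lie beyond the scatter, so compound 3 binds more weakly than the other two. Compound 4, `CN(c1ccc2cc(NC(=O)CCc3ccc(C(F)(F)F)cc3)ccc2n1)C1CCCC1`, has not yet been measured. It differs from compound 3 in one place: cyclopentyl in place of cyclohexyl on a nitrogen on an aromatic ring. The ring on that nitrogen loses one carbon, so compound 4 sits between compound 2, with its isopropyl, and compound 3, with its cyclohexyl, in the size of this group. The step of a 9.0-fold higher number from compound 2 to compound 3 (0.95 log units; beyond the scatter) shows that enlarging this group from isopropyl to cyclohexyl raised the number clearly; shrinking it part of the way back is therefore expected to lower the number, most likely by a modest amount, a 2.3-fold lower number from compound 3 to compound 4 (0.35 log units; beyond the scatter). Compound 4 is estimated at 8 nM, within a range of 3 nM to 25 nM.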

Compound 4, half-maximal inhibitory concentration: 2 nM
Estimate against measurement, compound 4: 4.0-fold (0.60 log units) above; the measured number lies below the stated range.
By their numbers in this assay, from the lowest: compounds 2, 4 and 1 (each within the scatter of the next); then compound 3.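

Going from cyclohexyl to cyclopentyl on this nitrogen gives a 9.0-fold lower number from compound 3 to compound 4 (0.95 log units; beyond the scatter) in this assay and shows that the removal of a single ring carbon can decide the result. Compound 4 also cannot be told apart from its neighbours, with no change at the digits printed from compound 2 to compound 4 (within the scatter) on exchanging isopropyl for cyclopentyl and a 2.0-fold lower number from compound 1 to compound 4 (0.30 log units; within the scatter) on exchanging azetidin-1-yl for cyclopentyl(methyl)amino. Among the four compounds, the groups up to cyclopentyl therefore give similar numbers, and only cyclohexyl stands apart, so the earlier rise does not build gradually with ring size across this set.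

Nothing measured here explains why one more ring carbon has this effect. Still open, from the compounds shown here alone, is what cyclobutyl, cycloheptyl or a six-membered ring containing oxygen, such as tetrahydropyran-4-yl, would give on this nitrogen.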